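A few compounds are considered here, and "the series" means these few. Any claim that something is new, unique, unknown or untested is made for them only; others in the source may bear on it.

In a functional assay on BGC-823 cells (Homo sapiens) for antiproliferative activity, read by MTT assay, with a stated time of 72 h (on this read-out higher numbers stand for weaker inhibition and lower numbers for stronger inhibition), compound 1 (`O=C(Nc1ccccc1)C(Cl)Cl`) stands at "not determined" (no result reported) and so offers no single number as a starting point. Compound 2 (`O=C(Nc1ccccc1Br)C(Cl)Cl`) is in the same position at "not determined" (no result reported) and adds no anchor either. Among the compounds with values here, the only number belongs to compound 3 (`COc1cccc(NC(=O)C(Cl)Cl)c1`) at 179000 nM in this assay and it is a single point.

Compound 4 (`O=C(Nc1ccc(I)cc1)C(Cl)Cl`) is still unmeasured and keeps the core of compound 1 with one change: iodo in place of hydrogen on an aromatic carbon. Within the data shown here, no measured step exists, so the data do not show what any change on this ring does. With no number for compound 1, the step can only be judged loosely. A moderate step toward stronger inhibition in this assay is expected, probably beyond the usual scatter, though on thin evidence. The closest reference is compound 3 at 179000 nM and the expectation is a result in the same broad range, somewhat on the stronger side of that value. For compound 4 the estimated half-maximal inhibitory concentration is 70000 nM with an expected range of 15000 nM to 250000 nM in this read-out.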

Compound 4, half-maximal inhibitory concentration: 222000 nM
For compound 4 the middle estimate is 3.2-fold (0.50 log units) below the measured one; the range from low to high includes it.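

No new step can be read in this assay: compound 4 stands at 222000 nM, while compound 1 offers no single number to set against it. Nothing available bears on the cause of this result. The compounds shown leave open how iodo in place of hydrogen changes inhibition on the core of compound 1.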